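The source may hold more compounds than are shown below. What is called first, only, known or untested is meant among the compounds shown, and "the series" means these compounds.

Working notes on the series. Among the measured compounds shown here, all three compounds measured so far share a core and are compared in an assay on CHO cells for displacement of a labelled ligand from prostaglandin D2 receptor 2 (Homo sapiens), read by scintillation counting; a lower number here means a stronger inhibitor, a higher number a weaker inhibitor. Compound 1 `CN(c1cccc(C#Cc2cc(Cl)ccc2OCC(=O)O)c1)S(C)(=O)=O` gives 122 nM in this assay. Compound 2 `CC1(C)C(=O)c2ccc(C#Cc3cc(Cl)ccc3OCC(=O)O)cc2S1(=O)=O` gives 31 nM. Compound 3 `Cc1ccc(S(=O)(=O)N2CCN(C)CC2)cc1C#Cc1cc(Cl)ccc1OCC(=O)O` gives 21 nM, the lowest of the three numbers; its gap to compound 2 lies within the scatter, so no order between those two can be read, while its gap to compound 1 lies beyond the scatter.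

The next compound, compound 4 `COCCNS(=O)(=O)c1ccc(C)c(C#Cc2cc(Cl)ccc2OCC(=O)O)c1`, has not been measured. It differs from compound 3 in one place: (2-methoxyethyl)amino in place of 4-methylpiperazin-1-yl on a sulfonyl sulfur. For the measured compounds named here, no pair of measured compounds differs in this way, so nothing here shows how the sulfonyl substituent affects the number.

Going by the values given here, with no precedent, the step from compound 3 to compound 4 is expected to be small, at most a modest rise, and possibly none beyond the scatter: a 1.4-fold higher number from compound 3 to compound 4 (0.15 log units; within the scatter). Compound 4 is therefore estimated at 30 nM in this assay, with a range from 10 nM to 90 nM.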

Compound 4, inhibition constant: 3.6 nM
Beside the measured number, compound 4's estimate is 8.3-fold (0.92 log units) above it; measured number below the stated range.
By their numbers in this assay, from the lowest: compound 4; then compounds 3 and 2 (each within the scatter of the next); then compound 1.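

In this assay, among the compounds shown here, (2-methoxyethyl)amino in place of 4-methylpiperazin-1-yl on a sulfonyl sulfur gives a 5.8-fold lower number from compound 3 to compound 4 (0.77 log units; beyond the scatter), so the number does respond to the group at this position, which no earlier pair could show. The change is not a single one: the ring leaves, an open chain enters, and the entering group has 1 hydrogen-bond donor where the leaving group has 0, so this one step cannot separate these differences. Nothing measured here accounts for the size of the step.

Still open, as far as these compounds go, is whether the chain's methoxy oxygen or the hydrogen on the sulfonamide nitrogen matters, which a plain propylamino group or an N-methyl-(2-methoxyethyl)amino group would test. A morpholin-4-yl group would show whether a ring at this position can give a similar number.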